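The source may hold more compounds than are shown below. What is called first, only, known or untested is meant among the compounds shown, and "the series" means these compounds.

In a functional assay on MDA-MB-231 cells (Homo sapiens) for antiproliferative activity, read by MTT assay, with a stated time of 48 h (on this read-out higher numbers stand for weaker inhibition and lower numbers for stronger inhibition), compound 1 (`COc1ccc(N(C)c2ccnc(Cl)n2)cc1F`) gives 1280 nM, compound 2 (`COc1ccc(N(C)c2ccnc(Cl)n2)cc1Cl`) gives 1380 nM and compound 3 (`COc1ccc(N(C)c2ccnc(Cl)n2)cc1O`) gives 833 nM. Compound 3 thus stands within the scatter of both others. Compound 4 (`COc1ccc(N(C)c2ccnc(Cl)n2)cc1OCCBr`) follows from compound 3 by 2-bromoethyl in place of hydrogen on an oxygen on an aromatic ring, or hydroxy to 2-bromoethoxy. The nearest measured changes are a 1.5-fold lower number from compound 1 to compound 3 (0.19 log units; within the scatter) and a 1.7-fold lower number from compound 2 to compound 3 (0.22 log units; within the scatter), alongside a 1.1-fold higher number from compound 1 to compound 2 (0.03 log units; within the scatter), and all stay within the scatter. For the measured compounds named here, no measured step puts a chain on that oxygen, so the basis is thin. In this assay, the expected result is a 1.0-fold lower number from compound 3 to compound 4 (0.02 log units; within the scatter), which means no step beyond the scatter. For compound 4 the estimate is 800 nM, with an expected range of 250 nM to 2500 nM.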

Compound 4, half-maximal inhibitory concentration: 6620 nM
Estimate against measurement, compound 4: 8.3-fold (0.92 log units) below; the whole stated range lies below it.
By their numbers in this assay, from the lowest: compounds 3, 1 and 2 (each within the scatter of the next); then compound 4.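

In this assay 2-bromoethyl on the oxygen gives a 7.9-fold higher number from compound 3 to compound 4 (0.90 log units; beyond the scatter) and so shows that this place does not take every change as quietly as the fluoro, chloro and hydroxy exchanges did. The same holds against the two halogen compounds, with a 4.8-fold higher number from compound 2 to compound 4 (0.68 log units; beyond the scatter) and a 5.2-fold higher number from compound 1 to compound 4 (0.71 log units; beyond the scatter) for 2-bromoethoxy in place of chloro and of fluoro. No evidence at hand bears on this result.

As far as these compounds go, whether the weaker number follows the chain itself or its bromine stays open. A plain ethoxy, a methoxy, a longer chain or an amine at the chain end would separate the two.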